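The source may report more compounds than this note shows. Statements on the series, on what has been measured and on what is new or still open speak of the compounds shown alone.

Compound 1 `Cc1nc(Nc2ccccc2)sc1C(=O)/C=C/c1ccc(Cl)cc1` was tested in a functional assay on NCI-H460 cells (Homo sapiens) for cytotoxicity, read by MTT assay; on this read-out lower numbers stand for stronger inhibition and higher numbers for weaker inhibition. In this assay compound 1 gives only a limit, > 25000 nM, not a number. Compound 2 `Cc1nc(Nc2ccccc2)sc1C(=O)/C=C/c1ccccc1Cl` likewise gives only a limit in this assay, > 25000 nM. Among the compounds with values here, the one measured step, a step that the two limits leave unreadable from compound 1 to compound 2, cannot be read because of the limit of > 25000 nM in this assay, at which 2 of the 2 values shown sit. Compound 3 `Cc1cccc(Nc2nc(C)c(C(=O)/C=C/c3ccc(Cl)cc3)s2)c1` differs from compound 1 by methyl in place of hydrogen on an aromatic carbon. No readable measured step bears on this change, so neither a direction nor a size can be drawn from the data. Compound 3 is expected to sit near the same limit, estimated at 30000 nM with a range from 8000 nM to 80000 nM. That estimate means a step that the limit leaves unreadable from compound 1 to compound 3.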

Compound 3, half-maximal inhibitory concentration: > 25000 nM
Compound 3 was reported as a limit; the forecaster's own chance of this, stated with the estimate: 75%; the middle value lies beyond the limit too.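

No new step can be read from compound 1 to compound 3, because both compounds give only a limit, not a number: the limit of > 25000 nM in this assay, at which 3 of the 3 values shown sit. The compounds shown leave open whether methyl in place of hydrogen changes the result at all in this assay.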